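A few compounds are considered here, and "the series" means these few. Any claim that something is new, unique, unknown or untested is made for them only; others in the source may bear on it.

Compound 1 `Cc1nc(C)c(C(=O)Oc2ccccc2/C=C/C(=O)O)nc1C`, compound 2 `COc1cc(/C=C/C(=O)O)ccc1OC(=O)c1nc(C)c(C)nc1C` and compound 3 `COc1ccc(OC(=O)c2nc(C)c(C)nc2C)c(/C=C/C(=O)O)c1` have been measured. In a functional assay on EA.hy 926 cells (Homo sapiens) for cytotoxicity, read by MTT assay, with stated times of 24 h and 12 h, tested at 50 uM (on this read-out higher numbers stand for a stronger effect at the one concentration tested and lower numbers for a weaker effect), compound 1 gives 64.9%. In this assay compound 3 gives 62.9%, and compound 2 gives 49.1%. The change methoxy in place of hydrogen on an aromatic carbon gave a number 2 percentage points lower from compound 1 to compound 3 (within the scatter). How the core of compound 2 differs from that of compound 1 is not broken down here.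

Compound 4 `COc1cc(/C=C/C(=O)O)cc(OC)c1OC(=O)c1nc(C)c(C)nc1C` is not yet measured; it differs from compound 2 by methoxy in place of hydrogen on an aromatic carbon. The surroundings are not identical: the entering methoxy now sits ortho to a large group and meta to a methoxy group, whereas in the earlier step it sat para to a large group, so this is the same kind of change, not the same change.

Resting on a number 2 percentage points lower from compound 1 to compound 3 (within the scatter), the expected step is a number 0.1 percentage points lower from compound 2 to compound 4 (within the scatter). Compound 4 is estimated at 49%, between 37% and 61%.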

Compound 4, a percentage reported as activity, at one concentration (the size of the read-out at that concentration, not a potency): 96.6%
Beside the measured number, compound 4's estimate is 47.6 percentage points below it; measured number outside the range, above it.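

Methoxy in place of hydrogen on an aromatic carbon gives a number 47.5 percentage points higher from compound 2 to compound 4 (beyond the scatter), with the entering group ortho to a large group and meta to a methoxy group. The step does not carry from one core to another at one fixed size in this series: the same change on two cores in this assay, a number 2 percentage points lower (within the scatter) from compound 1 to compound 3 and a number 47.5 percentage points higher (beyond the scatter) from compound 2 to compound 4, 49.5 percentage points apart, beyond the scatter of two such steps. The two steps also differ in where the methoxy enters, so these compounds do not separate the effect of the core from that of the place, and they give no cause for the gap.

On these data alone, it remains open whether a hydroxyl, an ethoxy or a chlorine at the same place would give a step of similar size. As far as these compounds go, it is also open whether the number for compound 4 holds at other concentrations.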